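Swapping the Ester Tail for an Acetamido Group

The source may hold more compounds than are shown below. What is called first, only, known or untested is meant among the compounds shown, and "the series" means these compounds.

Of the compounds shown here, two of a shared core have been measured in a functional assay on HT-1080 cells (Homo sapiens), read by transwell migration, with a stated time of 24 h, tested at 10 uM; on this read-out lower numbers stand for a stronger effect and higher numbers for a weaker effect at the one concentration tested. Compound 1 `CCCC(=O)OCc1ccc2oc(=O)c(C(=O)Oc3cccc(Br)c3)cc2c1` gives 24.7% in this assay. Compound 2 `CCCCCCC(=O)OCc1ccc2oc(=O)c(C(=O)Oc3cccc(Br)c3)cc2c1` gives 36%, the highest of the two numbers; its nearest neighbour is compound 1, and the step of a number 11.3 percentage points higher from compound 1 to compound 2 (beyond the scatter) lies beyond the scatter. Compound 3 `CC(=O)NCc1ccc2oc(=O)c(C(=O)Oc3cccc(Br)c3)cc2c1` remains to be measured. It differs from compound 2 by acetamido in place of (hexylcarbonyl)oxy on a saturated chain carbon bound to an aromatic carbon, with the new group sitting on a saturated chain carbon bound to an aromatic carbon. Going by the values given here, only one measured step bears on this change: the shortening of the chain from compound 2 back to compound 1 brought the number down by a modest amount, and compound 3 removes the chain altogether while bringing in a hydrogen-bond donor that neither measured compound carries. As far as these compounds go, on that single step, the account expects compound 3 to move downward, by about a number 10 percentage points lower from compound 2 to compound 3 (within the scatter), though the new acetamido group is untested and widens the range. The estimate for compound 3 in this assay is 26%, between 10% and 46%.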

Compound 3, a percentage reported as activity, at one concentration (the size of the read-out at that concentration, not a potency): 27.1%
Compound 3: the middle estimate sits 1.1 percentage points below what was measured; the measured number falls inside the stated range.
By their numbers in this assay, from the lowest: compounds 1, 3 and 2 (each within the scatter of the next, the first and the last beyond it).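

In this assay, an ester link on a saturated chain carbon bound to an aromatic carbon proves not to be needed for the read-out: acetamido at this place gives a number 8.9 percentage points lower from compound 2 to compound 3 (within the scatter) and a number 2.4 percentage points higher from compound 1 to compound 3 (within the scatter) and so cannot be told apart from either ester. The two esters themselves lie beyond the scatter of each other, yet compound 3, whose acetamido has 4 heavy atoms against the 9 of (hexylcarbonyl)oxy and carries a hydrogen-bond donor that neither ester has, falls within the scatter of both, so this place accepts a change in both the link and the size of the group without a readable loss or gain. Nothing available explains why the read-out behaves this way.

The compounds shown leave open whether a longer chain on the acetamido carbonyl would repeat the step seen among the esters, a number 11.3 percentage points higher from compound 1 to compound 2 (beyond the scatter), or whether the amide link would change how chain length counts. They also leave open how a free amine or a carboxylic acid on the same saturated chain carbon would read in this assay at the one concentration tested.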